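A few compounds are considered here, and "the series" means these few. Any claim that something is new, unique, unknown or untested is made for them only; others in the source may bear on it.

Of the compounds shown here, two have been tested in an assay on isolated protein (Bos taurus) with 5-hydroxytryptamine receptor 1D (Homo sapiens) as the target; a lower number here means a stronger inhibitor, a higher number a weaker inhibitor. Compound 1 `Fc1ccc2c(c1)CCC(CNCCCNC1=NCCCN1)O2` gives 7.94 nM in this assay. Compound 2 `c1cnc(NCCCNCC2CCc3ccccc3O2)nc1` gives 1.59 nM. Of these two numbers, compound 2 holds the lower one; compound 1 stands a good deal higher, and that gap lies beyond the usual scatter of repeated measurements, so compound 2 is the stronger inhibitor of the pair. Compound 3 `O=C1CCCN=C(NCCCNCC2CCc3ccccc3O2)N1` has not yet been measured. It differs from compound 2 in one place: a group of 8 heavy atoms (5 carbon, 2 nitrogen, 1 oxygen; one seven-membered non-aromatic ring with 2 hetero atoms) in place of a group of 6 heavy atoms (4 carbon, 2 nitrogen; one six-membered aromatic ring with 2 hetero atoms), on an amine nitrogen The pyrimidin-2-yl group on the amine nitrogen gives way to a seven-membered non-aromatic ring. For the measured compounds named here, no pair of measured compounds shows a change of this kind, so there is no measured step to lean on. Compound 3 is expected to give a somewhat higher number than compound 2 in this assay. The expected step is a 3.1-fold higher number from compound 2 to compound 3 (0.50 log units; beyond the scatter). The estimate for compound 3 is 5 nM, with a likely range from 1.5 nM to 20 nM.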

Compound 3, half-maximal inhibitory concentration: 158 nM
Estimate against measurement, compound 3: 32-fold (1.50 log units) below; measured number above the stated range.
By their numbers in this assay, from the lowest: compound 2; then compound 1; then compound 3.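

Replacing pyrimidin-2-yl on this amine nitrogen with the seven-membered non-aromatic ring brings a 99-fold higher number from compound 2 to compound 3 (2.00 log units; beyond the scatter) in this assay and shows that this position is far from indifferent to what it carries. The earlier compounds shown here could not show this, since they differ from each other in more than one place. The step changes several things at once, including ring size, aromatic against non-aromatic ring, and the gain of a hydrogen-bond donor, and no measurement here explains the loss.

Which of these changes matters remains open, as does whether a phenyl or pyridin-2-yl ring on this nitrogen would keep the low number of compound 2. A seven-membered ring without the carbonyl would separate ring size from that group.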